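The source may hold more compounds than are shown below. What is called first, only, known or untested is meant among the compounds shown, and "the series" means these compounds.

In a functional assay on NCI-H226 cells (Homo sapiens) for cytotoxicity, read by sulforhodamine B assay, with a stated time of 48 h (on this read-out lower numbers stand for stronger inhibition of growth and higher numbers for weaker inhibition of growth), two compounds have been measured so far. Compound 1 `ClCc1ccc(Cn2cnc3nc(Cl)nc(Cl)c32)cc1` gives 1230 nM. Compound 2 `ClCc1ccccc1Cn1cnc2ncnc(Cl)c21` gives 3380 nM, the higher of the two numbers, so its growth inhibition is the weaker of the pair, and the gap to compound 1 lies beyond the scatter. The two structures differ in more than one place, however, so no single change can be credited with that gap.

Compound 3 `ClCc1ccccc1Cn1cnc2nc(Cl)nc(Cl)c21` has not yet been measured. It arises from compound 2 by chloro in place of hydrogen on an aromatic carbon: a chloro group takes the place of a hydrogen on an aromatic carbon, between two ring nitrogen atoms of the fused core. Compound 1 likewise carries two chloro groups on its core and gives 1230 nM. On that basis a modest step toward a lower number is expected, with the caveat that compound 1 also differs in its benzyl part. The expected step is a 1.7-fold lower number from compound 2 to compound 3 (0.23 log units; within the scatter). Compound 3 is estimated at 2000 nM, with a range from 800 nM to 5000 nM.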

Compound 3, concentration for 50% growth inhibition: 2130 nM
Compound 3: the middle estimate sits 1.1-fold (0.03 log units) below what was measured; measured number inside the range.
By their numbers in this assay, from the lowest: compounds 1, 3 and 2 (each within the scatter of the next, the first and the last beyond it).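

Placing a chloro group on this aromatic carbon, between two ring nitrogen atoms, gives a 1.6-fold lower number from compound 2 to compound 3 (0.20 log units; within the scatter) in this assay, a step within the scatter, so compound 2 and compound 3 cannot be told apart on this read-out. Within the data shown here, this is the first direct comparison at this position, and it shows that the added chloro group leaves growth inhibition without any change that can be distinguished from ordinary repeat variation. No accompanying measurement bears on why the swap has so little visible effect here.

Going by these compounds, only hydrogen and chloro can be compared at this position, so the outcome with an amine or a methoxy group there remains open. On these data alone, it is also open whether the same swap would give a similar result with the benzyl part of compound 1.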